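A few compounds are considered here, and "the series" means these few. Any claim that something is new, unique, unknown or untested is made for them only; others in the source may bear on it.

Working notes on the series. The shared core carries a substituent on a nitrogen on an aromatic ring, and the three measured compounds vary only there. Compound 1 `CC(C)N(c1ccnc(Nc2ccc(C#N)cc2)n1)c1c(F)cc(-c2ccc(C#N)cc2)cc1F` bears isopropyl; compound 2 `N#Cc1ccc(Nc2nccc(N(c3c(F)cc(-c4ccc(C#N)cc4)cc3F)C3CCCC3)n2)cc1` bears cyclopentyl; compound 3 `C=CCN(c1ccnc(Nc2ccc(C#N)cc2)n1)c1c(F)cc(-c2ccc(C#N)cc2)cc1F` bears allyl. In an ADME assay on MT4 cells (Homo sapiens) for cytotoxicity, read by MTT assay, with a stated time of 5 days (on this read-out higher numbers stand for lower toxicity in this test and lower numbers for higher toxicity in this test), compound 1 gives 172000 nM, compound 2 gives 232000 nM and compound 3 gives 249000 nM. The steps between them are all small: a 1.3-fold higher number from compound 1 to compound 2 (0.13 log units; within the scatter), a 1.4-fold higher number from compound 1 to compound 3 (0.16 log units; within the scatter) and a 1.1-fold higher number from compound 2 to compound 3 (0.03 log units; within the scatter). Among the compounds with values here, compound 3 therefore stands with the other two inside the usual scatter of this assay, and no compound can be set apart.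

Compound 4 `CC(=O)N(c1ccnc(Nc2ccc(C#N)cc2)n1)c1c(F)cc(-c2ccc(C#N)cc2)cc1F` differs from compound 3 by acetyl in place of allyl on a nitrogen on an aromatic ring. Within the data shown here, none of the measured steps covers an acetyl at this position; the three steps that bear on the position, all within scatter, show that isopropyl, cyclopentyl and allyl there leave this assay unchanged. On that basis the step is expected to be a 1.1-fold lower number from compound 3 to compound 4 (0.05 log units; within the scatter), with no change beyond the scatter. Compound 4 is accordingly estimated at 220000 nM, in the range 90000 nM to 500000 nM.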

Compound 4, half-maximal cytotoxic concentration: > 268000 nM
Compound 4: a limit, no number; the forecaster's own chance of this, stated with the estimate: 30%; at least 1.2-fold (0.08 log units) between middle value and limit.
By their numbers in this assay, from the lowest: compounds 1, 2 and 3 (each within the scatter of the next). At a limit, above all of these: compound 4.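

In this assay compound 4 gives a limit and not a number: the limit of > 268000 nM in this assay, at which 1 of the 4 values shown sits. Read as floors, the steps are an at least 1.0-fold higher number from compound 3 to compound 4 (0.03 log units; that floor lies within the scatter), an at least 1.1-fold higher number from compound 2 to compound 4 (0.06 log units; that floor lies within the scatter) and an at least 1.5-fold higher number from compound 1 to compound 4 (0.19 log units; that floor lies within the scatter), which extends the position to its first group with an oxygen and a hydrogen-bond acceptor, with no fall in the number. As far as these compounds go, each floor lies within the scatter, so acetyl cannot be set apart from isopropyl, cyclopentyl or allyl on this nitrogen, and the full size of each step remains unknown.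

The compounds shown leave open whether an amine, a carboxylic acid or a longer chain on this nitrogen would also keep the number in this range. They also leave open how far the value of compound 4 lies past its limit.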